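Same Atoms, Rejoined: From Compound 1 to Compound 3

The source may hold more compounds than are shown below. What is called first, only, known or untested is meant among the compounds shown, and "the series" means these compounds.

In a functional assay on L1210 cells (Mus musculus) for inhibition (on this read-out lower numbers stand for stronger inhibition and higher numbers for weaker inhibition), two compounds have been measured so far. Compound 1 `NC1=NC(N)c2c(ncn2C=C=CCO)N1` gives 60000 nM, the lower of the two numbers and so the stronger inhibition. Compound 2 `Cc1cn(C=C=CCO)c(=O)nc1N` gives 620000 nM, a gap beyond the usual scatter. Compound 3 `NC1=NC(N)c2c(ncn2CC#CCO)N1` keeps the core of compound 1 and has the same atoms, joined differently: 4-hydroxybut-2-yn-1-yl in place of 4-hydroxybuta-1,2-dien-1-yl on an aromatic nitrogen. In words, 4-hydroxybut-2-yn-1-yl stands in place of 4-hydroxybuta-1,2-dien-1-yl on an aromatic nitrogen. For the measured compounds named here, no measured pair shows this exchange, so any forecast is loose. Going by the values given here, a change in the chain of the best compound so far seems more likely to lose inhibition than to gain it, and a moderate step toward a higher number in this assay is expected. The estimated change is a 3.3-fold higher number from compound 1 to compound 3 (0.52 log units; beyond the scatter). For compound 3 the expected value is 200000 nM, within an estimated range of 50000 nM to 800000 nM.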

Compound 3, half-maximal inhibitory concentration: 200000 nM
For compound 3 middle estimate and measured number coincide at the digits printed; the range from low to high includes it.
By their numbers in this assay, from the lowest: compound 1; then compound 3; then compound 2.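

In this assay, 4-hydroxybut-2-yn-1-yl in place of 4-hydroxybuta-1,2-dien-1-yl gives a 3.3-fold higher number from compound 1 to compound 3 (0.52 log units; beyond the scatter) with no change in the atoms present. This position on an aromatic nitrogen therefore responds to how the atoms of the chain are joined, and not only to which atoms it holds: two double bonds give way to one triple bond, while the heavy-atom, donor and acceptor counts stay the same. Nothing measured here gives a reason for this step.

Going by these compounds, it remains open whether a longer chain, or an amine in place of the hydroxy group at the chain end, would give a lower number than compound 1 does. On these data alone, it is also open whether the same exchange would shift the number in the same direction on the core of compound 2.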